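Swapping the bicyclic aromatic group in a urea series

The compounds below may be only part of what the source reports. "The series", "measured", "known", "first", "only" and "open" are said of these compounds alone.

Compound 1 `Cn1ccc2c(NC(=O)NCCN3CCC(O)(Cc4ccccc4)CC3)ccnc21`: 160 nM
Compound 2 `Cn1ccc2nccc(NC(=O)NCCN3CCC(O)(Cc4ccccc4)CC3)c21`: 600 nM

Of the compounds shown here, two have been measured in an assay on HEK293 cells for displacement of a labelled ligand from Urotensin-2 receptor (Homo sapiens); on this read-out lower numbers stand for stronger inhibition and higher numbers for weaker inhibition. Compound 1 gives 160 nM. Compound 2 gives 600 nM, the higher of the two numbers; the step of a 3.8-fold higher number from compound 1 to compound 2 (0.57 log units; beyond the scatter) is the only one measured, and it came from exchanging one bicyclic aromatic group on the amide-type nitrogen for another of the same size.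

Compound 3 `Cn1cnc2c(NC(=O)NCCN3CCC(O)(Cc4ccccc4)CC3)ccnc21` has not yet been measured. It differs from compound 2 in one place: a group of 10 heavy atoms (7 carbon, 3 nitrogen; one five-membered aromatic ring with 2 hetero atoms, one six-membered aromatic ring with 1 hetero atom) in place of a group of 10 heavy atoms (8 carbon, 2 nitrogen; one five-membered aromatic ring with 1 hetero atom, one six-membered aromatic ring with 1 hetero atom), on an amide-type nitrogen. The measured step bears on it only loosely, since it concerns a different pair of bicyclic groups on the same nitrogen, but it shows that such an exchange shifted the number by a modest amount. A step of similar size is therefore expected here, and the new group is expected to bring the number down rather than up, as a 2.4-fold lower number from compound 2 to compound 3 (0.38 log units; beyond the scatter). Compound 3 is estimated at 250 nM, within a range from 80 nM to 800 nM.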

Compound 3, half-maximal inhibitory concentration: 2140 nM
For compound 3 the middle estimate is 8.6-fold (0.93 log units) below the measured one, and the stated range ends below it.
By their numbers in this assay, from the lowest: compound 1; then compound 2; then compound 3.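

Among these compounds, the group with two hetero atoms in its five-membered aromatic ring does not lower the number in this assay; instead it gives a 3.6-fold higher number from compound 2 to compound 3 (0.55 log units; beyond the scatter). The comparison with compound 1 is especially telling, since a single carbon in the five-membered ring is exchanged for nitrogen while the group keeps its heavy-atom count, and this gives a 13-fold higher number from compound 1 to compound 3 (1.13 log units; beyond the scatter), so a very small change on the amide-type nitrogen can produce a large step, a larger one than the earlier pair alone had shown. Nothing measured here explains why binding responds in this way.

The compounds shown leave open whether the higher number follows from the added ring nitrogen itself or from where that nitrogen sits, since only one group of this kind appears here. They also leave open how the number would respond on the same amide-type nitrogen to a naphthyl group, which has only carbon in its rings, or to a single-ring phenyl group.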